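The source may hold more compounds than are shown below. What is called first, only, known or untested is meant among the compounds shown, and "the series" means these compounds.

Compound 1 `Oc1ccccc1-c1cc(-c2cccc(F)c2)cc(-c2ccccc2O)n1` is the reference point of this series. In a functional assay on DU-145 cells (Homo sapiens) for inhibition (on this read-out higher numbers stand for weaker inhibition and lower numbers for stronger inhibition), compound 1 gives > 50000 nM, which is a limit of the assay and not a number. Compound 2 `Oc1cccc(-c2cc(-c3cccc(F)c3)cc(-c3ccccc3O)n2)c1` also stops at a limit: in this assay compound 2 gives > 50000 nM. Two of the three measured values sit at this limit (the limit of > 50000 nM in this assay, at which 2 of the 3 values shown sit). For the measured compounds named here, compound 3 `Oc1ccccc1-c1cc(-c2ccccc2C(F)(F)F)cc(-c2ccccc2O)n1` is the one member with a number, giving 4770 nM in this assay. Going by the values given here, the step of an at least 10-fold lower number from compound 1 to compound 3 (1.02 log units; beyond the scatter) is the only readable change in the set, while the step that the two limits leave unreadable from compound 1 to compound 2 cannot be sized.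

Compound 4 `Oc1ccccc1-c1cc(-c2cccc(OC(F)(F)F)c2)cc(-c2ccccc2O)n1` differs from compound 1 by trifluoromethoxy in place of fluoro on an aromatic carbon. The measured step that bears on it is an at least 10-fold lower number from compound 1 to compound 3 (1.02 log units; beyond the scatter), since it also altered the 3-fluorophenyl group of compound 1, though with a different replacement. Compound 4 is therefore expected to come in lower than compound 1, with a step of an at least 2.0-fold lower number from compound 1 to compound 4 (0.30 log units; that floor lies within the scatter) estimated, though a limit may again be reported. Compound 4 is estimated at 25000 nM, within a range of 4000 nM to 100000 nM.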

Compound 4, half-maximal inhibitory concentration: 7470 nM
For compound 4 the middle estimate is 3.3-fold (0.52 log units) above the measured one, within the range that was stated.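

In this assay, changing only the group on this aromatic carbon, meta to a large group, is enough to bring the series off its limit: trifluoromethoxy in place of fluoro gives an at least 6.6-fold lower number from compound 1 to compound 4 (0.82 log units; beyond the scatter). The earlier readable step, 2-(trifluoromethyl)phenyl in place of 3-fluorophenyl, replaced the whole aryl group, whereas here the ring and the place of its substituent stay as they are. The step is a floor and not a full size, since compound 1 is one of the compounds held at a limit: the limit of > 50000 nM in this assay, at which 2 of the 4 values shown sit.

A single replacement at this carbon cannot separate the contribution of the oxygen from that of the three fluorines, and methoxy, trifluoromethyl or an amine there would bear on this. The effect of moving the hydroxyl, as in compound 2, remains unreadable.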